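The compounds below may be only part of what the source reports. "The series", "measured", "known", "first", "only" and "open" are said of these compounds alone.

In a functional assay on the whole organism (strain Kunming) with Mus musculus as the target, in the formalin test, with a stated time of 0.5 h (on this read-out lower numbers stand for an effect already at smaller amounts and higher numbers for an effect only at larger amounts of compound), compound 1 `COc1cc(OC)c(OC)cc1/C=C/COC(=O)/C=C/c1ccc(Br)cc1` gives 105 mg/kg and compound 2 `COc1cc(OC)c(OC)cc1/C=C/COC(=O)/C=C/c1ccccc1Cl` gives 101 mg/kg. Among the compounds with values here, these are the only two numbers so far, and they lie within the scatter of each other, so compound 2 stands level with compound 1. Compound 3 `COc1cc(OC)c(OC)cc1/C=C/COC(=O)/C=C/c1ccc(F)cc1` keeps the shared core and differs from compound 2 in one group: 4-fluorophenyl in place of 2-chlorophenyl on a double-bonded chain carbon bound to a double-bonded chain carbon. In short, 4-fluorophenyl takes the place of 2-chlorophenyl on a double-bonded chain carbon bound to a double-bonded chain carbon. Within the data shown here, one measured step bears on this, with 2-chlorophenyl in place of 4-bromophenyl at that same place: a 1.0-fold lower number from compound 1 to compound 2 (0.02 log units; within the scatter). Among the measured compounds shown here, no measured compound carries 4-fluorophenyl, so this rests on a single comparison. A change beyond the scatter is therefore not expected in this assay, in either direction. The expected step is a 1.0-fold higher number from compound 2 to compound 3 (0.02 log units; within the scatter). The estimate for compound 3 is 105 mg/kg, with an expected range from 60 mg/kg to 180 mg/kg.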

Compound 3, dose for half-maximal effect: 43.4 mg/kg
Compound 3: the middle estimate sits 2.4-fold (0.38 log units) above what was measured; measured number outside the range, below it.
By their numbers in this assay, from the lowest: compound 3; then compounds 2 and 1 (each within the scatter of the next).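

The group at this place does matter: the earlier swap of 4-bromophenyl for 2-chlorophenyl stayed within the scatter, but in this assay 4-fluorophenyl in place of 2-chlorophenyl brings a 2.3-fold lower number from compound 2 to compound 3 (0.37 log units; beyond the scatter) on a double-bonded chain carbon bound to a double-bonded chain carbon. Fluoro in place of bromo on an aromatic carbon gives a 2.4-fold lower number from compound 1 to compound 3 (0.38 log units; beyond the scatter) as a modest step, so exchanging that single halogen is enough to move the dose beyond the scatter. Nothing measured here explains why the fluoro compound needs a smaller dose.

The step from compound 2 to compound 3 changes both the halogen and its printed ring number, so these two changes cannot be separated. A 4-chlorophenyl group would help to separate them, while plain phenyl and 4-aminophenyl would show whether the trend extends beyond halogens.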